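This account rests on a few compounds, and the source may have more. Where it says the series, first, only, none or still open, it means among the compounds named here.

Compound 1 `O=c1[nH]/c(=N\OCCCc2cccc(F)c2)ccn1[C@@H]1O[C@H](COP(=O)(O)OP(=O)(O)OP(=O)(O)O)[C@@H](O)[C@H]1O` gives 190 nM in a functional assay on 1321-N1 cells for agonist activity at P2Y purinoceptor 2 (Homo sapiens), read by scintillation counting and inositol phosphate accumulation; a higher number here means that more compound is needed for the effect, a lower number that less compound is needed.
Compound 2 `COc1ccc(CCCO/N=c2/ccn([C@@H]3O[C@H](COP(=O)(O)OP(=O)(O)OP(=O)(O)O)[C@@H](O)[C@H]3O)c(=O)[nH]2)cc1` gives 47 nM in this assay.
Compound 3 `O=c1[nH]/c(=N\OCCCc2cccnc2)ccn1[C@@H]1O[C@H](COP(=O)(O)OP(=O)(O)OP(=O)(O)O)[C@@H](O)[C@H]1O` gives 327 nM in this assay.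

Compound 3 stands at the high end of these three numbers: compound 1 lies within the scatter of it a 1.7-fold higher number from compound 1 to compound 3 (0.24 log units; within the scatter), while compound 2 sits clearly lower a 7.0-fold higher number from compound 2 to compound 3 (0.84 log units; beyond the scatter). Compound 4 `O=c1[nH]/c(=N\OCCCc2ccsc2)ccn1[C@@H]1O[C@H](COP(=O)(O)OP(=O)(O)OP(=O)(O)O)[C@@H](O)[C@H]1O` differs from compound 3 in one place: thiophen-3-yl in place of pyridin-3-yl on a saturated chain carbon, three bonds along the chain from an oxygen. Among the measured compounds shown here, no measured step exchanges exactly these two rings, so the guide is how much the earlier ring swaps moved this assay: little in a 1.7-fold higher number from compound 1 to compound 3 (0.24 log units; within the scatter), modestly in a 7.0-fold higher number from compound 2 to compound 3 (0.84 log units; beyond the scatter). A change of similar size, at most modest and tending downward, is therefore expected. Compound 4 is estimated to give 180 nM, a step of a 1.8-fold lower number from compound 3 to compound 4 (0.26 log units; within the scatter), with a range from 60 nM to 500 nM.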

Compound 4, half-maximal effective concentration: 103 nM
Estimate against measurement, compound 4: 1.7-fold (0.24 log units) above, and the stated range covers the measured number.
By their numbers in this assay, from the lowest: compound 2; then compounds 4, 1 and 3 (each within the scatter of the next, the first and the last beyond it).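

Swapping pyridin-3-yl for thiophen-3-yl on this chain gives a real gain, a 3.2-fold lower number from compound 3 to compound 4 (0.50 log units; beyond the scatter), so the identity of the terminal ring matters even when the propyl chain stays the same. The thiophene does not match the 4-methoxyphenyl ring, a 2.2-fold higher number from compound 2 to compound 4 (0.34 log units; beyond the scatter), and it cannot be separated from the 3-fluorophenyl ring, a 1.8-fold lower number from compound 1 to compound 4 (0.27 log units; within the scatter). No supporting measurement accounts for these differences.

This swap changes ring size and hetero atom together, leaving their separate contributions unknown. The compounds shown also leave open how a furan-3-yl ring, an amine or a longer chain would behave here.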